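Swapping the Ring at the Chain End of Compound 2

The compounds below may be only part of what the source reports. "The series", "measured", "known", "first", "only" and "open" are said of these compounds alone.

In a functional assay (aorta) with Rattus norvegicus as the target (on this read-out higher numbers stand for weaker inhibition and lower numbers for stronger inhibition), compound 2 `CCO/C(O)=C1\C(COCCN2CC(=O)N=C2N)=NC(C)=C(C(=O)OC)C1c1ccccc1Cl` gives 20 nM, the highest number among the three measured compounds. Within the data shown here, compound 1 `CCO/C(O)=C1\C(COCCN2CC(=O)N(C)C2=O)=NC(C)=C(C(=O)OC)C1c1cccc(Cl)c1Cl` gives 5.01 nM, and compound 3 `CCO/C(O)=C1\C(COCCN2CC(=O)NC2=O)=NC(C)=C(C(=O)OC)C1c1cccc(Cl)c1Cl` gives 3.16 nM; compound 2 sits beyond the scatter from both, while the single measured step, a 1.6-fold lower number from compound 1 to compound 3 (0.20 log units; within the scatter), stays within it. Compound 4 `CCO/C(O)=C1\C(COCCn2ccnn2)=NC(C)=C(C(=O)OC)C1c1ccccc1Cl` differs from compound 2 in one place: a group of 5 heavy atoms (2 carbon, 3 nitrogen; one five-membered aromatic ring with 3 hetero atoms) in place of a group of 7 heavy atoms (3 carbon, 3 nitrogen, 1 oxygen; one five-membered non-aromatic ring with 2 hetero atoms), on a saturated chain carbon, two bonds along the chain from an oxygen on a saturated carbon. Among the measured compounds shown here, no measured step covers a change of this kind, since the step from compound 1 to compound 3 only exchanges a hydrogen for a methyl on a ring nitrogen and both carry a different aryl group from compound 2. With nothing that bears directly on it, the expectation is a small step in this assay, a 1.3-fold lower number from compound 2 to compound 4 (0.12 log units; within the scatter), with either direction possible. For compound 4 the estimated value in this assay is 15 nM, with a range from 4 nM to 60 nM.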

Compound 4, half-maximal inhibitory concentration: 15.9 nM
For compound 4 the middle estimate is 1.1-fold (0.03 log units) below the measured one; the range from low to high includes it.
By their numbers in this assay, from the lowest: compounds 3 and 1 (each within the scatter of the next); then compounds 4 and 2 (each within the scatter of the next).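

At this chain end, a saturated ring with 7 heavy atoms and 1 hydrogen-bond donor can give way to the smaller 1H-1,2,3-triazol-1-yl, an aromatic ring with 5 heavy atoms and 0 hydrogen-bond donors, and this assay cannot tell the two apart: a 1.3-fold lower number from compound 2 to compound 4 (0.10 log units; within the scatter). So, for this pair, neither the non-aromatic ring, its 2 double bonds outside aromatic rings nor its hydrogen-bond donor is needed to hold the number at this level. Nothing at hand explains why the read-out stays put under so large a change in structure.

On these data alone, whether the triazolyl group would behave the same way on the aryl group carried by compound 1 and compound 3 remains open. So does the outcome with a carboxylic acid or an amine at this chain end, or with a longer chain leading to the triazolyl ring.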